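A few compounds are considered here, and "the series" means these few. Any claim that something is new, unique, unknown or untested is made for them only; others in the source may bear on it.

Measured in a functional assay on PC-9 cells (Homo sapiens) for inhibition, read by MTT assay, with a stated time of 48 h, tested at 10 uM; on this read-out higher numbers stand for more inhibition at the one concentration tested (going by the name of the read-out) and lower numbers for less inhibition:
compound 1 `CCc1ccc(Nc2cc(NC(=O)Nc3c(Cl)cccc3Cl)ncn2)cc1` — 70.1%
compound 2 `COc1cc(Br)ccc1Nc1cc(NC(=O)Nc2c(Cl)cccc2Cl)ncn1` — 90.5%
compound 3 `Cc1ccc(Nc2cc(NC(=O)Nc3c(Cl)cccc3Cl)ncn2)cc1F` — 92%

Compound 1 stands lowest of the three; compound 2 lies a number 20.4 percentage points higher from compound 1 to compound 2 (beyond the scatter) and compound 3 lies a number 21.9 percentage points higher from compound 1 to compound 3 (beyond the scatter), while compound 3 differs from compound 2 by only a number 1.5 percentage points higher from compound 2 to compound 3 (within the scatter). Compound 4 `CC(C)(C)c1ccc(Nc2cc(NC(=O)Nc3c(Cl)cccc3Cl)ncn2)cc1` is the untested member; relative to compound 1 it shows (tert-butyl in place of ethyl on an aromatic carbon). Going by the values given here, both measured steps leaving compound 1 exchanged the whole aryl group for a differently substituted ring, and neither enlarges the ethyl group alone, so no step bears directly on this change. The two known steps suggest that compound 1 can be raised by changes on this ring, but the new change is smaller in kind. The expected step is estimated at about a number 4.9 percentage points higher from compound 1 to compound 4 (within the scatter), close to the scatter. Compound 4 is therefore estimated at 75%, ranging from 55% to 90%.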

Compound 4, a percentage reported as inhibition, at one concentration (the size of the read-out at that concentration, not a potency): 41.5%
Compound 4: middle estimate off by 33.5 percentage points, on the high side; measured number outside the range, below it.
By their numbers in this assay, from the lowest: compound 4; then compound 1; then compounds 2 and 3 (each within the scatter of the next).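

In this assay, tert-butyl in place of ethyl gives a number 28.6 percentage points lower from compound 1 to compound 4 (beyond the scatter). This is the only step shown that changes this one group alone, and it goes down, whereas both steps that exchanged the whole aryl group went up. The read-out at this aromatic carbon therefore depends on which alkyl group sits there, and nothing available explains the drop.

On these data alone, whether an isopropyl group here would land nearer compound 1 or compound 4 stays open. So does how an amine at this carbon would compare.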